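A few compounds are considered here, and "the series" means these few. Any claim that something is new, unique, unknown or untested is made for them only; others in the source may bear on it.

Compound 1 `COc1cc(/C=C/C(=O)C2=C(/C=C/c3ccc(O)c(OC)c3)NC(=O)NC2c2ccccc2)ccc1O` carries, on the aromatic ring attached to the saturated carbon of its core, only hydrogen. In a functional assay, with a stated time of 20 min, tested at 2 uM (a lower number here means a weaker effect, a higher number a stronger effect of the compound at the concentration tested), compound 1 gives 15.2%. Compound 2 `COc1cc(/C=C/C(=O)C2=C(/C=C/c3ccc(O)c(OC)c3)NC(=O)NC2c2ccc(O)cc2)ccc1O` bears a hydroxy on that ring in place of hydrogen, and in this assay compound 2 gives 25%. The step of a number 9.8 percentage points higher from compound 1 to compound 2 (within the scatter) is the only one measured so far, and it is within the scatter, so compound 2 and compound 1 cannot be told apart on these numbers; compound 2 simply has the higher of two numbers that sit within scatter of each other.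

Compound 3 `COc1cc(/C=C/C(=O)C2=C(/C=C/c3ccc(O)c(OC)c3)NC(=O)NC2c2ccc(N(C)C)cc2)ccc1O` differs from compound 2 by dimethylamino in place of hydroxy on an aromatic carbon. Among the measured compounds shown here, no measured step covers this change; the one measured step, hydroxy in place of hydrogen, was within the scatter. On that basis no step beyond the scatter is expected for no change at the digits printed from compound 2 to compound 3 (within the scatter). Compound 3 is therefore estimated at 25% in this assay, with a range from 10% to 40%.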

Compound 3, a percentage reported as activity, at one concentration (the size of the read-out at that concentration, not a potency): 17.9%
The estimate for compound 3 lay 7.1 percentage points above the measured number; the range from low to high includes it.
By their numbers in this assay, from the lowest: compounds 1, 3 and 2 (each within the scatter of the next).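

With dimethylamino in place of hydroxy on this aromatic carbon, para to a large group, this assay shows a number 7.1 percentage points lower from compound 2 to compound 3 (within the scatter), and with dimethylamino in place of hydrogen it shows a number 2.7 percentage points higher from compound 1 to compound 3 (within the scatter). This position now holds three different substituents, hydrogen, hydroxy and dimethylamino, and the three compounds cannot be told apart on these numbers: going from hydroxy, with its hydrogen-bond donor and single heavy atom, to dimethylamino, with no donor and three heavy atoms, produces no step beyond the scatter. No other measurement is available that could explain these numbers.

The compounds shown leave open whether a carboxylic acid, a fluorine atom or a longer chain such as butoxy on this same carbon would give a number that stands clear of the scatter around these three. Each number also comes from a single concentration, so it gives the size of the effect of compound 1, compound 2 and compound 3 at that concentration and nothing beyond it.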